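The compounds below may be only part of what the source reports. "The series", "measured", "known", "first", "only" and "open" are said of these compounds alone.

Compound 1, `Cc1ccc(C#Cc2cn(C/C=C\CN3C(=O)c4ccccc4C3=O)c(=O)[nH]c2=O)cc1`, and compound 2, `CCCCCC#Cc1cn(C/C=C/CN2C(=O)c3ccccc3C2=O)c(=O)[nH]c1=O`, were both examined in a functional assay on SW-620 cells (Homo sapiens) for antiproliferative activity, read by MTT assay, with a stated time of 3 days; on this read-out lower numbers stand for stronger inhibition and higher numbers for weaker inhibition. Compound 1 reaches only a limit of this assay, giving > 100000 nM, which is a limit and not a number. Going by the values given here, compound 2 gives 58000 nM in this assay, and among the two values shown this is the only actual number, the other being (the limit of > 100000 nM in this assay, at which 1 of the 2 values shown sits). Compound 3, `CCCCC#Cc1cn(C/C=C/CN2C(=O)c3ccccc3C2=O)c(=O)[nH]c1=O`, has not yet been measured in this assay. It differs from compound 2 by hydrogen in place of methyl on a saturated chain carbon, four bonds along the chain from a triple-bonded carbon; in plain words, the chain attached to the triple bond is shortened by one carbon. Among the compounds with values here, no pair of measured compounds isolates this kind of change, so nothing measured fixes its size or direction. The expectation is that the step of a 1.3-fold higher number from compound 2 to compound 3 (0.11 log units; within the scatter) is small, not clearly beyond the usual scatter, with a slight weakening as the more likely side. Compound 3 is therefore estimated to give about 75000 nM in this assay, within a range from 30000 nM to 150000 nM, with a real chance that only a limit is reported.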

Compound 3, half-maximal inhibitory concentration: > 100000 nM
Compound 3 was reported as a limit; the forecaster's own chance of this, stated with the estimate: 30%; at least 1.3-fold (0.12 log units) between middle value and limit.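

Going by these compounds alone, the change, hydrogen in place of methyl on a saturated chain carbon, four bonds along the chain from a triple-bonded carbon, can now be read for the first time in this assay, and the reading is an at least 1.7-fold higher number from compound 2 to compound 3 (0.23 log units; that floor lies within the scatter). Because that figure is only a floor, and one that lies within the scatter, it shows no gain from the shorter chain but does not establish a real loss either. Compound 2 remains the only compound shown with an actual number, so this position is being read at the edge of what the assay can report: the limit of > 100000 nM in this assay, at which 2 of the 3 values shown sit.

The compounds shown leave open how large the step from the shorter chain truly is, and whether a longer chain on the triple bond would give a lower number than compound 2 gives or would leave the value unchanged. They also leave open whether an amine or a carboxylic acid at the end of that chain would bring the value clearly within the measurable range of this assay.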